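The source may hold more compounds than are shown below. What is called first, only, known or untested is meant among the compounds shown, and "the series" means these compounds.

Compound 1 `CN1CCN(CCCS(=O)(=O)c2ccc3nc(NC(=O)NC(=O)c4cccc(-n5cccn5)c4Cl)sc3c2)CC1`: 12 nM
Compound 2 `CN1CCN(CCCS(=O)(=O)c2ccc3nc(NC(=O)NC(=O)c4cc(-n5cccn5)ccc4Cl)sc3c2)CC1`: 1200 nM
Compound 3 `CN1CCN(CCCS(=O)(=O)c2ccc3nc(NC(=O)NC(=O)c4cc(-n5cccc5)ccc4Cl)sc3c2)CC1`: 580 nM

In an ADME assay on the whole organism (strain Han-Wistar) for pharmacokinetics, with Rattus norvegicus as the target, read by LC-MS, at a dose of 2 mg/kg by the oral route (a lower number here means less compound in the circulation, a higher number more compound in the circulation at the dose given), compound 2 gives the highest number of the three; the nearest is a 2.1-fold lower number from compound 2 to compound 3 (0.32 log units; beyond the scatter) and the furthest is a 100-fold higher number from compound 1 to compound 2 (2.00 log units; beyond the scatter). Compound 4 `CN1CCN(CCCS(=O)(=O)c2ccc3nc(NC(=O)NC(=O)c4cc5c(ccn5C)cc4Cl)sc3c2)CC1` has not been measured. The change is 5-chloro-1-methyl-1H-indol-6-yl in place of 2-chloro-5-(1H-pyrazol-1-yl)phenyl on a carbonyl carbon. Of the measured steps, a 2.1-fold lower number from compound 2 to compound 3 (0.32 log units; beyond the scatter) bears on it most closely, a modest shift when one five-membered ring replaces another; the large steps of a 100-fold higher number from compound 1 to compound 2 (2.00 log units; beyond the scatter) and a 48-fold higher number from compound 1 to compound 3 (1.68 log units; beyond the scatter) show that exchanging one chloro-phenyl pattern for another can move the number greatly, though neither pair matches this change. A modest lowering in this assay is expected, a 2.0-fold lower number from compound 2 to compound 4 (0.30 log units; within the scatter), with wide uncertainty. Compound 4 is estimated at 600 nM, range 150 nM to 2400 nM.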

Compound 4, maximal plasma concentration: 300 nM
Compound 4: middle estimate off by 2.0-fold (0.30 log units), on the high side, and the stated range covers the measured number.
By their numbers in this assay, from the lowest: compound 1; then compounds 4 and 3 (each within the scatter of the next); then compound 2.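

In this assay, the step of a 25-fold higher number from compound 1 to compound 4 (1.40 log units; beyond the scatter) shows that 5-chloro-1-methyl-1H-indol-6-yl on the carbonyl carbon stays far from the low number of the 2-chloro-3-(1H-pyrazol-1-yl)phenyl group, so a separate azole ring is not required among these compounds. Against the pyrazole group the fused ring gives up some exposure, with a 4.0-fold lower number from compound 2 to compound 4 (0.60 log units; beyond the scatter), while a 1.9-fold lower number from compound 3 to compound 4 (0.29 log units; within the scatter) leaves it not distinguishable from the pyrrole group. No measurement here accounts for these steps.

Still open, from the compounds shown here alone, is how a 5-fluoro group or a 1-ethyl group on the indole would read.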